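Chlorophenyl for Methoxyphenyl on a Piperazine Nitrogen

A few compounds are considered here, and "the series" means these few. Any claim that something is new, unique, unknown or untested is made for them only; others in the source may bear on it.

Compound 1 `COc1cccc(N2CCN(CC(=O)N3CCN(c4nnc(-c5ccccc5)c(-c5ccccc5)n4)CC3)CC2)c1` gives 361000 nM in an ADME assay on NIH3T3 cells (Mus musculus) for cytotoxicity, read by MTT assay, with a stated time of 24 h; a lower number here means a stronger inhibitor, a higher number a weaker inhibitor. Compound 2 `Cc1ccc(-c2nnc(N3CCN(C(=O)CN4CCN(c5ccc(Cl)cc5)CC4)CC3)nc2-c2ccc(C)cc2)cc1` gives 567000 nM in this assay. For compound 3 `COc1ccc(-c2nnc(N3CCN(C(=O)CN4CCN(c5ccccc5OC)CC4)CC3)nc2-c2ccc(OC)cc2)cc1` this assay reports only a limit, > 821000 nM, and no number. Among the compounds with values here, compound 3 therefore stands at the weak end of the three values shown, as the limit of > 821000 nM in this assay, at which 1 of the 3 values shown sits, tells, and no measured step links it to the other two. Compound 4 `COc1ccc(-c2nnc(N3CCN(C(=O)CN4CCN(c5ccc(Cl)cc5)CC4)CC3)nc2-c2ccc(OC)cc2)cc1` differs from compound 3 by 4-chlorophenyl in place of 2-methoxyphenyl on an amine nitrogen in a ring. Compound 2 carries the same 4-chlorophenyl group on its ring nitrogen and sits at 567000 nM. Compound 4 is expected at 650000 nM, within a range from 300000 nM to 1000000 nM. The expected step is an at least 1.2-fold lower number from compound 3 to compound 4 (0.10 log units; that floor lies within the scatter), which may well stay within the scatter, and a limit remains a real possibility.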

Compound 4, half-maximal inhibitory concentration: > 814000 nM
Compound 4: a limit, no number (the forecaster's own chance of this, stated with the estimate: 45%); middle value at least 1.2-fold (0.09 log units) from the limit.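

In this assay, compound 3 and compound 4 both give only a limit, and the step between them cannot be read. On these data alone, whether 4-chlorophenyl in place of 2-methoxyphenyl on an amine nitrogen in a ring changes the value at all stays open.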